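This account rests on a few compounds, and the source may have more. Where it says the series, first, only, none or still open, it means among the compounds named here.

Compound 2 `Fc1ccc2nc(-c3cccnn3)n(C3CC3)c2c1` carries a pyridazin-3-yl group on the shared core. In an ADME assay on cells for inhibition of cytochrome P450 11B1, mitochondrial (Homo sapiens), read by HPLC, with a stated time of 60 min (a lower number here means a stronger inhibitor, a higher number a weaker inhibitor), compound 2 gives only a limit, > 10000 nM. Compound 1 `Fc1ccc2nc(-c3cnccn3)n(C3CC3)c2c1`, with pyrazin-2-yl instead, likewise reaches only a limit in this assay, > 10000 nM. The step that the two limits leave unreadable from compound 1 to compound 2 therefore cannot be read, since the limit of > 10000 nM in this assay, at which 2 of the 2 values shown sit, holds both values shown. Compound 3 `Fc1ccc2nc(-c3ccnnc3)n(C3CC3)c2c1` differs from compound 2 by pyridazin-4-yl in place of pyridazin-3-yl on an aromatic carbon. Within the data shown here, the only measured step, from compound 1 to compound 2, also concerns an exchange of the six-membered heteroaryl group on an aromatic carbon of the core, and its size is not readable; no step of readable size bears on the change to compound 3. With both measured values sitting at the limit, the expected step is a step that the limit leaves unreadable from compound 2 to compound 3, nothing beyond the scatter. The estimate for compound 3 in this assay is 12000 nM, with a range from 3000 nM to 50000 nM, and the result is expected most likely to come back again only as a limit.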

Compound 3, half-maximal inhibitory concentration: > 10000 nM
Compound 3 gave a limit, no number; the forecaster's own chance of this, stated with the estimate: 85%; the middle value does not contradict the limit.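

In this assay no new step can be read among compound 1, compound 2 and compound 3, since all three give only a limit: the limit of > 10000 nM in this assay, at which 3 of the 3 values shown sit. The compounds shown leave open how the pyrazin-2-yl, pyridazin-3-yl and pyridazin-4-yl groups on the shared core rank in this assay and which change to the core would give a readable number.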